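This account rests on a few compounds, and the source may have more. Where it says the series, first, only, none or still open, it means among the compounds named here.

Compound 1 `CC(C)(C)OC(=O)CC[C@H](NC(=O)c1cc(Cl)ccc1OCCNC(=O)OC(C)(C)C)C(=O)Nc1ccc([N+](=O)[O-])cc1Cl` carries a tert-butoxycarbonyl group on its chain amine. In a functional assay on MCF7 cells (Homo sapiens) for inhibition, read by MTT assay, with a stated time of 72 h (a higher number here means a weaker inhibitor, a lower number a stronger inhibitor), compound 1 gives only a limit of the assay, > 10000 nM. Compound 2 `CC(C)(C)OC(=O)CC[C@H](NC(=O)c1cc(Cl)ccc1OCCN)C(=O)Nc1ccc([N+](=O)[O-])cc1Cl` differs from it by hydrogen in place of tert-butoxycarbonyl on an amine nitrogen, and compound 2 reaches 3080 nM, so that the step of an at least 3.2-fold lower number from compound 1 to compound 2 (0.51 log units; beyond the scatter) is read against the limit (the limit of > 10000 nM in this assay, at which 1 of the 3 values shown sits).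

Compound 3 `CC(C)[C@H](NC(=O)c1cc(Cl)ccc1OCCNC(=O)OC(C)(C)C)C(=O)Nc1cc(F)cc(C(F)(F)F)c1` is built on a different core; the difference between the two cores is not broken down here. In this assay compound 3 gives 11500 nM. Compound 4 `CC(C)[C@H](NC(=O)c1cc(Cl)ccc1OCCN)C(=O)Nc1cc(F)cc(C(F)(F)F)c1` differs from compound 3 by hydrogen in place of tert-butoxycarbonyl on an amine nitrogen, the same change made at the same place as before. The author expects a step of about a 3.0-fold lower number from compound 3 to compound 4 (0.48 log units; beyond the scatter), resting on the step from compound 1 to compound 2, an at least 3.2-fold lower number from compound 1 to compound 2 (0.51 log units; beyond the scatter). For compound 4 the estimated value is therefore 3800 nM, with a range of 1500 nM to 10000 nM.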

Compound 4, half-maximal inhibitory concentration: > 10000 nM
Compound 4: no number, only a limit (the forecaster's own chance of this, stated with the estimate: 20%); middle value at least 2.6-fold (0.42 log units) from the limit.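

Compound 4 gives only a limit in this assay, so the step from compound 3 to compound 4 cannot be read: the limit of > 10000 nM in this assay, at which 2 of the 4 values shown sit.

On these data alone, whether hydrogen in place of tert-butoxycarbonyl lowers the number on the core of compound 3, as it does on the core of compound 1, stays open.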